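Methyl on the central ring of a urea series

A few compounds are considered here, and "the series" means these few. Any claim that something is new, unique, unknown or untested is made for them only; others in the source may bear on it.

Measured in an assay on isolated protein for inhibition of proto-oncogene tyrosine-protein kinase receptor Ret (Homo sapiens), read by 33P incorporation, with stated times of 15 min and 40 min; a lower number here means a stronger inhibitor, a higher number a weaker inhibitor:
Compound 1 `Cc1cc(C)cc(NC(=O)Nc2ccc(Nc3ncnc4c3OCCN4)cc2)c1` gives 1070 nM.
Compound 2 `CC(C)(C)c1cc(NC(=O)Nc2ccc(Nc3ncnc4c3OCCN4)cc2)no1` gives 10 nM.

Compound 2 holds the lower of the two numbers; the only other point sits a 110-fold lower number from compound 1 to compound 2 (2.03 log units; beyond the scatter). Compound 3 `Cc1cc(NC(=O)Nc2cc(C(C)(C)C)on2)ccc1Nc1ncnc2c1OCCN2` differs from compound 2 by methyl in place of hydrogen on an aromatic carbon. Going by the values given here, the one measured step exchanged the group on the amide-type nitrogen and says nothing about a methyl on the central ring, so no measured pair bears on this change. The step to compound 3 is therefore expected to be small, none beyond the scatter, as a 1.2-fold higher number from compound 2 to compound 3 (0.08 log units; within the scatter). Compound 3 is estimated at 12 nM, range 4 nM to 40 nM.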

Compound 3, half-maximal inhibitory concentration: 50 nM
Compound 3: the middle estimate sits 4.2-fold (0.62 log units) below what was measured, and the stated range ends below it.
By their numbers in this assay, from the lowest: compound 2; then compound 3; then compound 1.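

Methyl in place of hydrogen on an aromatic carbon of this six-membered ring, ortho to a large group and meta to a large group, does not pass unnoticed: in this assay the change gives a 5.0-fold higher number from compound 2 to compound 3 (0.70 log units; beyond the scatter). This carbon of the ring therefore responds to a single added carbon, though the step is modest. Nothing at hand gives a reason for this loss.

Open, going by these compounds, is whether fluorine, methoxy or ethyl on the same carbon would give a similar step. Also open, on these data alone, is how methyl behaves on the other carbons of this ring.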